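Carbamoyl in place of phenyl: expected potency

A few compounds are considered here, and "the series" means these few. Any claim that something is new, unique, unknown or untested is made for them only; others in the source may bear on it.

In a functional assay on MIA PaCa-2 cells (Homo sapiens) for cytotoxicity, read by MTT assay, with a stated time of 72 h (a higher number here means a weaker inhibitor, a lower number a stronger inhibitor), compound 1 `O=C1C(Nc2ccc(-c3ccccc3)cc2)=CC(=O)c2ncncc21` gives 900 nM, the lowest number among the three measured. Compound 2 `COc1cccc(NC2=CC(=O)c3ncncc3C2=O)c1` gives 1800 nM in this assay, a value within the scatter of compound 1, so no order between the two is claimed. Compound 3 `O=C1C=CC(=O)c2ncncc21`, the core alone, gives 9400 nM in this assay, beyond the scatter from compound 1. Compound 4 `NC(=O)c1ccc(NC2=CC(=O)c3ncncc3C2=O)cc1` differs from compound 1 by carbamoyl in place of phenyl on an aromatic carbon. For the measured compounds named here, no measured pair shows this change, so the expectation rests only on the spread seen across the three compounds. The estimated step of a 1.7-fold higher number from compound 1 to compound 4 (0.22 log units; within the scatter) is small, toward a higher number, and may fall within the scatter. Compound 4 is expected to give about 1500 nM in this assay, with a range from 600 nM to 4000 nM.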

Compound 4, half-maximal inhibitory concentration: 8000 nM
Estimate against measurement, compound 4: 5.3-fold (0.73 log units) below; measured number above the stated range.
By their numbers in this assay, from the lowest: compounds 1 and 2 (each within the scatter of the next); then compounds 4 and 3 (each within the scatter of the next).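

With phenyl replaced by carbamoyl on the aromatic carbon in this assay, the series shows an 8.9-fold higher number from compound 1 to compound 4 (0.95 log units; beyond the scatter), so the group at this place does affect the number. For the compounds shown here, this is the first single-place change read, and it goes toward a weaker inhibitor. Nothing available bears on the reason for this step.

Open, on these data alone, is whether a pyridine ring here would stay close to compound 1, and whether an amine, a methyl or a carboxylic acid would stay close to compound 4.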